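Trading a fluorinated ether for a hydroxyalkyl group

This account rests on a few compounds, and the source may have more. Where it says the series, first, only, none or still open, it means among the compounds named here.

Of the compounds shown here, two sharing one core have been measured in a functional assay on HEK293 cells for antagonist activity at transient receptor potential M8 protein (Canis lupus familiaris), read by FLIPR and calcium flux; a lower number here means a stronger inhibitor, a higher number a weaker inhibitor. Compound 1 `FC(F)(F)Oc1ccccc1-c1ccc2[nH]c(C3=NOC4(CCCCC4)C3)nc2c1` gives 1.1 nM. Within the data shown here, compound 2 `FC(F)Oc1ccccc1-c1ccc2[nH]c(C3=NOC4(CCCCC4)C3)nc2c1` gives 2.5 nM, the higher of the two numbers: the single step of a 2.3-fold higher number from compound 1 to compound 2 (0.36 log units; beyond the scatter) shows what removing one fluorine from the ether group costs. Compound 3 `CC(C)(O)c1ccccc1-c1ccc2[nH]c(C3=NOC4(CCCCC4)C3)nc2c1` carries a different change at the same position: 1-hydroxy-1-methylethyl in place of difluoromethoxy on an aromatic carbon, on an aromatic carbon of a six-membered aromatic ring of carbon only, ortho to a large group. Among the measured compounds shown here, no measured step covers this swap directly; only the step from compound 1 to compound 2 touches this position, and it already moved the number beyond the scatter, so a further move in the same direction is expected for compound 3, of modest to moderate size a 3.2-fold higher number from compound 2 to compound 3 (0.51 log units; beyond the scatter). In this assay compound 3 is therefore estimated at 8 nM, within a range from 2 nM to 30 nM.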

Compound 3, half-maximal inhibitory concentration: 7.9 nM
Compound 3: the middle estimate sits 1.0-fold (0.01 log units) above what was measured, within the range that was stated.
By their numbers in this assay, from the lowest: compound 1; then compound 2; then compound 3.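

In this assay, replacing difluoromethoxy with 1-hydroxy-1-methylethyl gives a weaker inhibitor (a 3.2-fold higher number from compound 2 to compound 3 (0.50 log units; beyond the scatter)), and replacing trifluoromethoxy with the same group gives a larger loss (a 7.2-fold higher number from compound 1 to compound 3 (0.86 log units; beyond the scatter)). The position is therefore not restricted to fluorinated ethers: a group with no fluorine and with one hydrogen-bond donor still gives measurable inhibition, though the fluorinated ethers in compound 1 and compound 2 give the lower numbers. No measurement here explains why the number rises with this change.

Going by these compounds, what remains open is whether the hydroxyl or the two methyl groups of the new group matter more for this rise. On these data alone, it is also open where a plain methoxy group, an amine or a carboxylic acid on this aromatic carbon would fall relative to these three compounds.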